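The source may hold more compounds than are shown below. What is called first, only, known or untested is meant among the compounds shown, and "the series" means these compounds.

Measured compounds and their values:

Compound 1 `COc1ccc(Nc2nc(Oc3cccc(NC(=O)C=C(C)C)c3)c3sccc3n2)cc1`: 17600 nM
Compound 2 `COc1ccc(Nc2nc(Oc3cccc(NC(=O)/C=C/C(C)C)c3)c3sccc3n2)cc1`: 25200 nM
Compound 3 `CC/C=C/C(=O)Nc1cccc(Oc2nc(Nc3cccc(OC)c3)nc3ccsc23)c1`: 29200 nM

In a functional assay on A-431 cells (Homo sapiens) for inhibition, read by MTT assay, with a stated time of 72 h (on this read-out lower numbers stand for stronger inhibition and higher numbers for weaker inhibition), compound 1 gives 17600 nM, the lowest of the three numbers, though all three lie within the usual scatter of one another. Compound 2 differs from compound 1 only at the carbonyl carbon, and the step of a 1.4-fold higher number from compound 1 to compound 2 (0.16 log units; within the scatter) is within the scatter. For compound 1 and compound 3 only the two values themselves are known, and they too sit close together.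

The unmeasured compound 4 `CC(C)=CC(=O)Nc1cccc(Oc2nc(Nc3cccc(C#N)c3)nc3ccsc23)c1` keeps the shared core of compound 1 and changes the aryl amine instead: 3-cyanophenyl in place of 4-methoxyphenyl on a nitrogen on an aromatic ring. Among the compounds with values here, none of the measured steps touches this part of the molecule, so nothing measured bears directly on it; the only measured step, from compound 1 to compound 2, concerns the amide side chain and was within the scatter. With no evidence of a change beyond the scatter anywhere in this small set, the expectation for compound 4 is a step of about a 1.1-fold higher number from compound 1 to compound 4 (0.06 log units; within the scatter) in this assay, that is, no change beyond the scatter in either direction. Compound 4 is therefore estimated at 20000 nM, with a range from 6000 nM to 65000 nM.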

Compound 4, half-maximal inhibitory concentration: 28300 nM
Beside the measured number, compound 4's estimate is 1.4-fold (0.15 log units) below it; measured number inside the range.
By their numbers in this assay, from the lowest: compounds 1, 2, 4 and 3 (each within the scatter of the next).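

In this assay, within the data shown here, the aryl amine, which no earlier step had touched, gives a 1.6-fold higher number from compound 1 to compound 4 (0.21 log units; within the scatter) when 3-cyanophenyl replaces 4-methoxyphenyl on the nitrogen. Among these compounds, this is the first reading at this position, and it shows that the exchange of these two groups, of equal heavy-atom count, does not move the number beyond the scatter; the earlier step concerned only the amide side chain. No measured evidence bears on this result.

The compounds shown leave open how a carboxylic acid, a morpholine or a chlorine on this aromatic ring would read, or a longer chain in place of the methoxy group. They also leave open whether 3-cyanophenyl would read alike when paired with the 3-methylbut-1-en-1-yl side chain of compound 2, as each change is seen only singly.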